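The compounds below may be only part of what the source reports. "The series", "measured", "known", "first", "only" and "open" are said of these compounds alone.

Compound 1 `O=C(O)c1ccc(C(=O)/C(=C\c2ccc(F)c([N+](=O)[O-])c2)SCc2ccc(Cl)cc2Cl)cc1` carries a 4-fluoro-3-nitrophenyl group; in a physicochemical assay for solubility (a higher number here means a more soluble compound, a lower number a less soluble compound), compound 1 gives < 1000 ug/mL, a limit of the assay rather than a number. Compound 2 `O=C(O)c1ccc(C(=O)/C(=C\c2ccc(Br)c([N+](=O)[O-])c2)SCc2ccc(Cl)cc2Cl)cc1` differs by bromo in place of fluoro on an aromatic carbon. In this assay compound 2 gives < 1000 ug/mL, again a limit. The step that the two limits leave unreadable from compound 1 to compound 2 cannot be sized because of the limit of < 1000 ug/mL in this assay, at which 3 of the 3 values shown sit. Compound 3 `O=C(O)c1ccc(C(=O)/C(=C\c2ccc(Br)c([N+](=O)[O-])c2)SCc2ccc(F)cc2)cc1` has another core; the difference between the two cores is not broken down here, and the step that the two limits leave unreadable from compound 2 to compound 3 is likewise unreadable. In this assay compound 3 gives < 1000 ug/mL, once more a limit. Compound 4 `O=C(O)c1ccc(C(=O)/C(=C\c2ccc(Br)c([N+](=O)[O-])c2)SCc2ccc(Br)cc2)cc1` is unmeasured and differs from compound 3 by bromo in place of fluoro on an aromatic carbon. This is the same kind of change as seen earlier, but there the place was also ortho to a nitro group, whereas here it is only para to a large group. The expected step that the limit leaves unreadable from compound 3 to compound 4 rests solely on all three measured values sitting at the limit. Compound 4 is therefore expected to give about 200 ug/mL in this assay, within 30 ug/mL to 900 ug/mL.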

Compound 4, solubility: < 1000 ug/mL
Compound 4 ended at the assay's limit; the forecaster's own chance of this, stated with the estimate: 85%; the middle value does not contradict the limit.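

No new step can be read between compound 3 and compound 4, or between compound 2 and compound 4, because the values stop at one shared limit: the limit of < 1000 ug/mL in this assay, at which 4 of the 4 values shown sit.

The compounds shown leave open the actual solubility of all four and the size of any difference among them.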